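Removing a methoxy from compound 1

The compounds below may be only part of what the source reports. "The series", "measured", "known", "first", "only" and "open" are said of these compounds alone.

Going by the values given here, compound 1 `COc1ccc(CNc2nc3cc(N)cc(N)c3nc2-c2ccccc2)cc1OC` gives 33100 nM in a functional assay on ACHN cells (Homo sapiens) for inhibition, read by sulforhodamine B assay, with a stated time of 48 h (on this read-out lower numbers stand for stronger inhibition of growth and higher numbers for weaker inhibition of growth), the higher of the two numbers measured so far. Among the compounds with values here, compound 2 `COc1cc(CNc2nc3cc(N)cc(N)c3nc2-c2ccccc2)cc(OC)c1OC` gives 11200 nM in this assay; the step of a 3.0-fold lower number from compound 1 to compound 2 (0.47 log units; beyond the scatter) is the only measured step and it adds a methoxy. Compound 3 `COc1ccc(CNc2nc3cc(N)cc(N)c3nc2-c2ccccc2)cc1` differs from compound 1 by hydrogen in place of methoxy on an aromatic carbon, a methoxy taken away rather than added. Within the data shown here, with one modest step in the opposite direction as the sole guide, a modest rise in the number is expected for compound 3, a 1.8-fold higher number from compound 1 to compound 3 (0.26 log units; within the scatter). Compound 3 is therefore estimated at 60000 nM, within 25000 nM to 150000 nM.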

Compound 3, concentration for total growth inhibition: 33900 nM
Estimate against measurement, compound 3: 1.8-fold (0.25 log units) above; the range from low to high includes it.
By their numbers in this assay, from the lowest: compound 2; then compounds 1 and 3 (each within the scatter of the next).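

In this assay, going from 3,4-dimethoxyphenyl to 4-methoxyphenyl gives a 1.0-fold higher number from compound 1 to compound 3 (0.01 log units; within the scatter), so at this position, ortho to a methoxy group, hydrogen and methoxy cannot be told apart. Methoxy changes therefore do not all move the number, since a 3.0-fold lower number from compound 1 to compound 2 (0.47 log units; beyond the scatter) remains the only step beyond the scatter. Nothing available explains this difference between the two steps. Still open, as far as these compounds go, is whether an amine, a carboxylic acid or a longer chain at this position would shift the number. Also open, from the compounds shown here alone, is what replacing the remaining methoxy would do.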